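Trifluoromethyl in place of methyl: notes on compound 3

This account rests on a few compounds, and the source may have more. Where it says the series, first, only, none or still open, it means among the compounds named here.

In a functional assay on T47D cells (Homo sapiens) for inhibition, read by CCK-8 assay, with a stated time of 72 h, tested at 1 uM (a higher number here means more inhibition of growth at the concentration tested, a lower number less inhibition of growth), compound 2 `Cc1ccc(NC(=O)C2(C(=O)Nc3ccc(Nc4ncc5cc(C(=O)N(C)C)n(C6CCCC6)c5n4)cc3)CC2)cc1` gives 47.9% and stands highest of the two measured compounds. In this assay compound 1 `CN(C)C(=O)c1cc2cnc(Nc3ccc(NC(=O)C4(C(=O)Nc5ccc(Cl)c(C(F)(F)F)c5)CC4)cc3)nc2n1C1CCCC1` gives 6.9% by comparison. Compound 3 `CN(C)C(=O)c1cc2cnc(Nc3ccc(NC(=O)C4(C(=O)Nc5ccc(C(F)(F)F)cc5)CC4)cc3)nc2n1C1CCCC1` carries trifluoromethyl in place of methyl on an aromatic carbon, para to a large group trifluoromethyl in place of methyl on an aromatic carbon with the rest of compound 2 unchanged. For the measured compounds named here, only one measured step bears on this change, a large one: a number 41 percentage points higher from compound 1 to compound 2 (beyond the scatter) on going from 4-chloro-3-(trifluoromethyl)phenyl to 4-methylphenyl. The 4-(trifluoromethyl)phenyl of compound 3 shares trifluoromethyl with the group of compound 1 but has no chloro. No measurement separates the two substituents, so a partial return along that step is assumed. A fall is expected, estimated at a number 22.9 percentage points lower from compound 2 to compound 3 (beyond the scatter) and so smaller than that large step. For compound 3 the estimate is 25% with an expected range of 8% to 48% in this assay for now.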

Compound 3, percent growth inhibition at one concentration: 29.6%
For compound 3 the middle estimate is 4.6 percentage points below the measured one; the range from low to high includes it.
By their numbers in this assay, from the lowest: compound 1; then compound 3; then compound 2.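

At this position on the 4-methylphenyl ring, trifluoromethyl in place of methyl costs growth inhibition by itself in this assay, with a number 18.3 percentage points lower from compound 2 to compound 3 (beyond the scatter). The large drop seen earlier therefore does not depend on the chloro group alone, as compound 3 has no chloro and still falls short of compound 2. The 4-chloro-3-(trifluoromethyl)phenyl group of compound 1 loses further ground, as the step to the 4-(trifluoromethyl)phenyl group shows a number 22.7 percentage points higher from compound 1 to compound 3 (beyond the scatter), although that step changes the group as a whole and cannot assign the gain to one substituent. No data at hand explain either step.

Open, on these data alone, is how methoxy, an amine or a carboxylic acid in place of methyl on this ring would read in this assay. Also open, as far as these compounds go, is whether any group here exceeds the methyl of compound 2.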